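The source may report more compounds than this note shows. Statements on the series, on what has been measured and on what is new or still open speak of the compounds shown alone.

Of the compounds shown here, two on the shared core have been measured in a functional assay on PC-3 cells (Homo sapiens) for inhibition, read by sulforhodamine B assay, with a stated time of 48 h; a higher number here means a weaker inhibitor of growth, a lower number a stronger inhibitor of growth. Compound 1 `Fc1ccc(Cn2cc(CCCOc3cccc4cccnc34)nn2)cc1` gives 20.1 ug/mL in this assay, and compound 2 `Clc1ccc(Cn2cc(CCCOc3cccc4cccnc34)nn2)cc1` gives 3.6 ug/mL. For the measured compounds named here, the single measured step between them, a 5.6-fold lower number from compound 1 to compound 2 (0.75 log units; beyond the scatter), is the only comparison available, and it bears directly on the change now considered. On these two numbers compound 2 stands lowest, with compound 1 the nearest at a higher number.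

Compound 3 `Fc1ccc(Cn2cc(CCCOc3cccc4cccnc34)nn2)cc1F` is the next compound; against compound 2 the change is 3,4-difluorophenyl in place of 4-chlorophenyl on a saturated chain carbon bound to an aromatic nitrogen. This reverses the chloro-for-fluoro exchange of the measured step and adds a second fluorine. The measured step therefore points toward a higher number for compound 3 than for compound 2. Going by the values given here, the second fluorine has no precedent among the measured compounds, so its contribution cannot be read from the data, and the expectation rests on the measured step alone, tempered toward the middle. Compound 3 is expected to come out near 10 ug/mL, within 4 ug/mL to 25 ug/mL. This amounts to an expected step of a 2.8-fold higher number from compound 2 to compound 3 (0.44 log units; beyond the scatter).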

Compound 3, concentration for 50% growth inhibition: 6.6 ug/mL
Compound 3: the middle estimate sits 1.5-fold (0.18 log units) above what was measured; the measured number falls inside the stated range.
By their numbers in this assay, from the lowest: compounds 2 and 3 (each within the scatter of the next); then compound 1.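

In this assay, exchanging the 4-chlorobenzyl group for 3,4-difluorobenzyl gives a 1.8-fold higher number from compound 2 to compound 3 (0.26 log units; within the scatter), so the two groups cannot be told apart at this place, on a saturated chain carbon bound to an aromatic nitrogen. For the compounds shown here, the second comparison is the first to change the number of halogens on the ring: fluoro in place of hydrogen on an aromatic carbon gives a 3.0-fold lower number from compound 1 to compound 3 (0.48 log units; beyond the scatter). Fluorine on this ring therefore does not by itself go with the number seen for compound 1, since compound 3 also carries fluorine and stands within the scatter of chlorine-bearing compound 2, and nothing available here bears on the reason for either step.

Going by these compounds alone, with only three halogen-bearing benzyl groups, it remains open whether the result for compound 3 extends to other substituents on this ring, such as bromine, a methoxy group or an amine. The compounds also leave open how a shorter or longer chain in place of the three-carbon link in the shared core would behave in this assay, and whether the differences among these benzyl groups would persist with that change.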